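The compounds below may be only part of what the source reports. "The series", "measured", "known", "first", "only" and "open" are said of these compounds alone.

Working notes on the series. All three measured compounds share one core and differ only in the group on the carbonyl carbon of the amide: compound 1 `CS(=O)(=O)c1ccc(C(=O)Nc2ccc(Cl)c(-c3nnc4c(Cl)cccn34)c2)c(Cl)c1`, compound 2 `O=C(Nc1ccc(Cl)c(-c2nnc3c(Cl)cccn23)c1)c1ccccc1` and compound 3 `Cc1nc(C(=O)Nc2ccc(Cl)c(-c3nnc4c(Cl)cccn34)c2)cs1`. In a functional assay on A549 cells (Homo sapiens) for antiproliferative activity, read by MTT assay, with a stated time of 72 h (a higher number here means a weaker inhibitor, a lower number a stronger inhibitor), compound 1 reports only a limit, > 100000 nM. In this assay compound 2 gives 76900 nM. In this assay compound 3 also reports only a limit, > 100000 nM. Compound 3 therefore stands at the edge of what the assay reads, alongside (the limit of > 100000 nM in this assay, at which 2 of the 3 values shown sit), and no exact half-maximal inhibitory concentration is known for it. Within the data shown here, the single measured step, an at least 1.3-fold higher number from compound 2 to compound 3 (0.11 log units; that floor lies within the scatter), stays within the scatter at its floor, so the exchange of phenyl for 2-methyl-1,3-thiazol-4-yl moved the number little as far as can be told.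

Compound 4 `O=C(Nc1ccc(Cl)c(-c2nnc3c(Cl)cccn23)c1)c1cccc(Cl)c1` is not yet measured. It differs from compound 3 by 3-chlorophenyl in place of 2-methyl-1,3-thiazol-4-yl on a carbonyl carbon. The nearest reference is compound 2, whose phenyl at the same place gave 76900 nM. Given an at least 1.3-fold higher number from compound 2 to compound 3 (0.11 log units; that floor lies within the scatter), a step of an at least 1.4-fold lower number from compound 3 to compound 4 (0.15 log units; that floor lies within the scatter) is expected, small and toward a lower number, its size uncertain while only a limit is known at the start. Compound 4 is expected at 70000 nM, within 30000 nM to 150000 nM.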

Compound 4, half-maximal inhibitory concentration: 52700 nM
Compound 4: middle estimate off by 1.3-fold (0.12 log units), on the high side; the range from low to high includes it.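

With a second exact reading on this carbonyl carbon, the exchange of 2-methyl-1,3-thiazol-4-yl for 3-chlorophenyl in this assay can now be read from one side as a number, as an at least 1.8-fold lower number from compound 3 to compound 4 (0.27 log units; that floor lies within the scatter). Chloro in place of hydrogen on an aromatic carbon gives a 1.5-fold lower number from compound 2 to compound 4 (0.16 log units; within the scatter), so in this series the added chloro cannot be told apart from hydrogen. Compound 3 remains a limit and not a number, so the true size of the step from it is unknown, and the series stays close to the edge of what the assay reads: the limit of > 100000 nM in this assay, at which 2 of the 4 values shown sit.

As far as these compounds go, whether an amine, a carboxylic acid or a longer alkyl chain on this carbonyl carbon, in place of the aromatic ring, would move the number beyond the scatter from the phenyl reading remains open. Also open is whether a methoxy or a nitrile on the phenyl would do more than chloro, as the two exact readings shown differ only by that one chloro.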